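This account rests on a few compounds, and the source may have more. Where it says the series, first, only, none or still open, it means among the compounds named here.

Measured compounds in the series:

compound 1 `Oc1ccc(-c2ccc(F)cc2F)cc1-c1nnc(NC2CCCCC2)s1` — 41.4%
compound 2 `Oc1ccc(-c2ccc(F)cc2F)cc1-c1nnc(NC2CCCCC2)o1` — 23.8%
compound 3 `Cc1ccc(Nc2nnc(-c3cc(-c4ccc(F)cc4F)ccc3O)s2)cc1` — 43.5%

All three were run in a functional assay on the whole organism (strain BALB/c) for inhibition, with Mus musculus as the target, read by paw edema, with a stated time of 4 h, at a dose of 50 mg/kg by the oral route; on this read-out lower numbers stand for less inhibition and higher numbers for more inhibition at the one dose given (going by the name of the read-out). Compound 1 gives 41.4% and compound 3 gives 43.5% in this assay; the step between them is a number 2.1 percentage points higher from compound 1 to compound 3 (within the scatter), made by 4-methylphenyl in place of cyclohexyl on a nitrogen on an aromatic ring. Compound 2 gives 23.8% in this assay and stands lowest of the three, with its gaps to compound 1 and to compound 3 both beyond the scatter. The difference between the core of compound 1 and the core of compound 2 is not broken down here.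

Compound 4 `Cc1ccc(Nc2nnc(-c3cc(-c4ccc(F)cc4F)ccc3O)o2)cc1` has not yet been measured in this assay. For the measured compounds named here, it differs from compound 2 by 4-methylphenyl in place of cyclohexyl on a nitrogen on an aromatic ring, the same change, at the same place, as the one carried out from compound 1 to compound 3. Going by the values given here, since that earlier step, a number 2.1 percentage points higher from compound 1 to compound 3 (within the scatter), stayed within the scatter, the step from compound 2 to compound 4 is expected to be of a like size, a number 2.2 percentage points higher from compound 2 to compound 4 (within the scatter), because the only measured example of this change, a number 2.1 percentage points higher from compound 1 to compound 3 (within the scatter), produced no movement beyond the scatter. On that basis compound 4 is estimated at 26% in this assay. Among the compounds with values here, the expected range for compound 4 runs from 13% to 40%, resting on a single precedent pair and on the one measured value of compound 2.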

Compound 4, a percentage reported as inhibition, in the whole organism at one dose (the size of the read-out at that dose, not a potency): 33.8%
The estimate for compound 4 lay 7.8 percentage points below the measured number; measured number inside the range.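

In this assay, 4-methylphenyl in place of cyclohexyl on a nitrogen on an aromatic ring has now been read on two cores, and the new step is a number 10 percentage points higher from compound 2 to compound 4 (within the scatter). Set beside the earlier step, the new one does not differ from it by more than repeated measurement allows: the same change on two cores in this assay, a number 2.1 percentage points higher (within the scatter) from compound 1 to compound 3 and a number 10 percentage points higher (within the scatter) from compound 2 to compound 4, 7.9 percentage points apart, within the scatter of two such steps. Across these two cores the change stayed within the scatter on each and the steps give no sign of depending on the core, but with one pair per core this does not show that the change is without effect, that the two steps are equal, or that the same would hold on any further core.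

The compounds shown carry only cyclohexyl and 4-methylphenyl on that nitrogen, which leaves open how an open-chain amine, a carboxylic acid or a longer alkyl chain in that place would read. From the compounds shown here alone, the read-out also stands at a single oral dose and a single time, so the size of this step at other doses or times remains open.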